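This account rests on a few compounds, and the source may have more. Where it says the series, first, only, none or still open, it means among the compounds named here.

In a functional assay on MCF7 cells (Homo sapiens) for inhibition, read by sulforhodamine B assay, with a stated time of 48 h, tested at 10 uM (on this read-out lower numbers stand for less inhibition of growth and higher numbers for more inhibition of growth at the one concentration tested), compound 1 (`C/C(=N\O)c1ccc(NC(=O)Cn2nc(-c3ccc(Cl)cc3)nc2N)cc1`) gives 15.9% and compound 2 (`COc1ccc(-c2nc3sc(-c4ccccc4)cn3n2)cc1`) gives 74% at the one concentration tested. Among the measured compounds shown here, compound 2 therefore holds the higher of the only two numbers available, and the gap between them lies beyond the scatter. These two compounds differ in many places, so their gap cannot be traced to any single group. Compound 3 (`c1ccc(-c2nc3sc(-c4ccccc4)cn3n2)cc1`) keeps the core of compound 2 with one change: hydrogen in place of methoxy on an aromatic carbon. For the measured compounds named here, no measured pair here shows what such a swap does, so any expectation remains loose. In this assay a moderate loss of growth inhibition is expected (estimated step a number 14 percentage points lower from compound 2 to compound 3 (beyond the scatter)), although a result within the scatter of compound 2 would be no surprise. The estimated value for compound 3 is 60% (expected range 35% to 85%).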

Compound 3, percent growth inhibition at one concentration: 61%
Estimate against measurement, compound 3: 1 percentage points below; the range from low to high includes it.
By their numbers in this assay, from the lowest: compound 1; then compound 3; then compound 2.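

Among the compounds shown here, replacing methoxy with hydrogen on this aromatic carbon, para to a large group, gives the first direct reading of this place in this assay: a number 13 percentage points lower from compound 2 to compound 3 (beyond the scatter). The methoxy group is therefore not essential for growth inhibition at the one concentration tested, since compound 3 still gives 61% with only hydrogen there, yet removing it has a modest effect that lies beyond the usual scatter. No supporting measurement points to the reason for this step.

As far as these compounds go, it remains open whether a hydroxyl group, an amine or a longer ethoxy chain at this place would give a value near compound 2, near compound 3 or outside that span. It is also unclear whether the same swap would produce a step of similar size elsewhere on the shared core.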